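A few compounds are considered here, and "the series" means these few. Any claim that something is new, unique, unknown or untested is made for them only; others in the source may bear on it.

Measured in a functional assay on HepG2 cells (Homo sapiens) for antiproliferative activity, read by MTT assay, with a stated time of 72 h; on this read-out higher numbers stand for weaker inhibition and lower numbers for stronger inhibition:

- Compound 1 `O=C1COc2ccc(-c3cccc(NS(=O)(=O)c4ccc(F)cc4)c3)cc2N1`: > 40000 nM (a limit)
- Compound 2 `O=C1COc2ccc(-c3cccc(NS(=O)(=O)c4ccc(F)cc4)c3)cc2N1c1ccccc1`: 30300 nM
- Compound 3 `O=C1COc2ccc(-c3cccc(NS(=O)(=O)c4ccc(F)cc4)c3)cc2N1C1CC1`: > 40000 nM (a limit)

Compound 3 has no exact number, only the limit > 40000 nM. Exact numbers are scarce in this small set: the limit of > 40000 nM in this assay, at which 2 of the 3 values shown sit.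

The next structure is compound 4 `O=C1COc2ccc(-c3cccc(NS(=O)(=O)c4ccc(F)cc4)c3)cc2N1c1ccc(F)cc1`. The change is 4-fluorophenyl in place of cyclopropyl on an amide-type nitrogen in a ring.

The closest measured step is the reverse kind of swap on that same nitrogen, phenyl to cyclopropyl, which gives an at least 1.3-fold higher number from compound 2 to compound 3 (0.12 log units; that floor lies within the scatter). Going from hydrogen to phenyl at this position gives an at least 1.3-fold lower number from compound 1 to compound 2 (0.12 log units; that floor lies within the scatter). Going from hydrogen to cyclopropyl gives a step that the two limits leave unreadable from compound 1 to compound 3. Together, these steps offer only a weak hint that an aromatic ring here may lower the number, and no large step is expected.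

For the measured compounds named here, compound 2 is the one measured compound with a six-membered aromatic ring of carbon only on that nitrogen, and it gives 30300 nM, so that value anchors the expectation. The expected change is small: an at least 1.3-fold lower number from compound 3 to compound 4 (0.12 log units; that floor lies within the scatter), an estimate set against a limit rather than a number. Another limit from this assay would not be surprising.

For compound 4 the estimated value is 30000 nM, with an expected range from 15000 nM to 50000 nM.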

Compound 4, half-maximal inhibitory concentration: > 40000 nM
Compound 4 gave a limit, no number; the forecaster's own chance of this, stated with the estimate: 40%; at least 1.3-fold (0.12 log units) between middle value and limit.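

The new comparison concerns the aromatic ring itself rather than the choice of group on the amide-type nitrogen: fluoro in place of hydrogen on an aromatic carbon gives an at least 1.3-fold higher number from compound 2 to compound 4 (0.12 log units; that floor lies within the scatter) in this assay and does not establish that the fluoro makes a real difference. For the compounds shown here, the weak hint that an aromatic ring on this nitrogen might lower the number therefore does not carry over to 4-fluorophenyl, and compound 2, with phenyl, remains the only compound here with an exact value. The steps from compound 1 and from compound 3 to compound 4 cannot be read, and the position remains hard to judge because most results are limits rather than numbers: the limit of > 40000 nM in this assay, at which 3 of the 4 values shown sit.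

Going by these compounds, it remains open whether any group on this nitrogen, such as a short chain ending in an amine or a carboxylic acid, would give an exact number clearly lower than that of compound 2. On these data alone, it is also open whether replacing the 4-fluorophenyl with a pyridine ring would change the result, or whether changes elsewhere on the shared core matter more than those at this position.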